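The compounds below may be only part of what the source reports. "The series", "measured", "known", "first", "only" and "open" are said of these compounds alone.

Measured compounds:
compound 1, `O=C(O)CCCN1Cc2ccc(NC(=O)CC3CCNCC3)cc2C1=O`, 1800 nM
compound 2, `O=C(O)CCN1Cc2ccc(NC(=O)c3ccc(C4CCNCC4)cc3)cc2C1=O`, 9600 nM

In a functional assay on a cell-free system (Platelet, plasma, Homo sapiens) for inhibition (on this read-out lower numbers stand for stronger inhibition and higher numbers for weaker inhibition), compound 1 gives 1800 nM, the lowest of the two numbers available. Compound 2 gives 9600 nM, a higher number that lies beyond the scatter, so compound 1 is the stronger inhibitor of this pair. For the measured compounds named here, compound 2 differs from compound 1 in more than one place, and no single step is drawn between them; their two values show only the gap itself.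

Compound 3, `O=C(O)CCN1Cc2ccc(NC(=O)CC3CCNCC3)cc2C1=O`, has not yet been measured in this assay. It differs from compound 1 by carboxy in place of carboxymethyl on a saturated chain carbon, two bonds along the chain from an amide-type nitrogen in a ring. Going by the values given here, no measured pair isolates this change, so any expectation rests on the structural change alone. A modest weakening is expected, with the estimated step being a 1.9-fold higher number from compound 1 to compound 3 (0.29 log units; within the scatter). Compound 3 is accordingly estimated at 3500 nM, with a likely range from 900 nM to 14000 nM.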

Compound 3, half-maximal inhibitory concentration: 7400 nM
Estimate against measurement, compound 3: 2.1-fold (0.33 log units) below; low and high end bracket the measured number.
By their numbers in this assay, from the lowest: compound 1; then compounds 3 and 2 (each within the scatter of the next).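

Read in this assay the change from 3-carboxypropyl to 2-carboxyethyl gives a 4.1-fold higher number from compound 1 to compound 3 (0.61 log units; beyond the scatter) and so provides the first isolated reading at this position. The length of this acid-bearing chain therefore matters on the shared core, and of the two lengths compared, the 3-carboxypropyl chain of compound 1 gives the lower number. No evidence at hand explains the step.

The compounds shown leave open whether a longer chain, such as 4-carboxybutyl, would lower the number further or whether the shorter carboxymethyl would raise it again. They also leave open whether the carboxylic acid itself is needed at the chain end, or whether a primary amide or a tetrazole could stand in its place.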